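Fluoro in Place of Hydrogen on Compound 2

The source may report more compounds than this note shows. Statements on the series, on what has been measured and on what is new or still open speak of the compounds shown alone.

Of the compounds shown here, three sharing one core have been measured in a functional assay on A549 cells (Homo sapiens) for inhibition, read by MTT assay, with a stated time of 72 h; a higher number here means a weaker inhibitor, a lower number a stronger inhibitor. There, compound 1 `C=C(Cl)C(=O)Nc1cc(Nc2nc3c(c(-c4cn(C)c5ccccc45)n2)CS(=O)(=O)CC3)c(OC)cc1N(C)CCN(C)C` gives 881 nM, compound 2 `COc1cc(N(C)CCN(C)C)c(NC(=O)C=C(C)C)cc1Nc1nc2c(c(-c3cn(C)c4ccccc34)n1)CS(=O)(=O)CC2` gives 787 nM and compound 3 `C/C=C\C(=O)Nc1cc(Nc2nc3c(c(-c4cn(C)c5ccccc45)n2)CS(=O)(=O)CC3)c(OC)cc1N(C)CCN(C)C` gives 4260 nM. The two lower numbers cannot be told apart, with a 1.1-fold lower number from compound 1 to compound 2 (0.05 log units; within the scatter). Compound 2 therefore shares the low end of this small set, while the third number stands apart, with a 5.4-fold higher number from compound 2 to compound 3 (0.73 log units; beyond the scatter) and a 4.8-fold higher number from compound 1 to compound 3 (0.68 log units; beyond the scatter).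

Compound 4 `COc1cc(N(C)CCN(C)C)c(NC(=O)C=C(C)C)cc1Nc1nc2c(c(-c3cn(C)c4ccc(F)cc34)n1)CS(=O)(=O)CC2` carries a different change: fluoro in place of hydrogen on an aromatic carbon. This is fluoro in place of hydrogen on an aromatic carbon, turning 1-methyl-1H-indol-3-yl into 5-fluoro-1-methyl-1H-indol-3-yl. Among the measured compounds shown here, none of the measured steps bears directly on it, since all three alter only the group on the carbonyl carbon. With no guide to size or direction, the expectation stays anchored on compound 2 at 787 nM. The expected change is no step beyond the scatter, an estimated 1.1-fold lower number from compound 2 to compound 4 (0.05 log units; within the scatter). For compound 4 the expected value is 700 nM, within an estimated range of 300 nM to 1600 nM.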

Compound 4, half-maximal inhibitory concentration: 2140 nM
Estimate against measurement, compound 4: 3.1-fold (0.49 log units) below; measured number outside the range, above it.
By their numbers in this assay, from the lowest: compounds 2 and 1 (each within the scatter of the next); then compounds 4 and 3 (each within the scatter of the next).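

In this assay, among the compounds shown here, the earlier steps altered only the group on the carbonyl carbon, so they said nothing about the 1-methyl-1H-indol-3-yl group. The change to 5-fluoro-1-methyl-1H-indol-3-yl shows that this position is not indifferent: a single added fluorine atom gives a 2.7-fold higher number from compound 2 to compound 4 (0.43 log units; beyond the scatter), a modest step towards a weaker inhibitor. No measurement available here explains this shift.

From the compounds shown here alone, whether the step belongs to fluoro in particular remains open, and a chloro, methoxy or nitrile group on the same aromatic carbon would help to settle it. Also open is whether fluoro has a similar effect when the carbonyl carbon carries the 1-chloroethenyl group of compound 1 or the prop-1-en-1-yl group of compound 3, since only the 2-methylprop-1-en-1-yl pair is shown.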